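The source may hold more compounds than are shown below. What is called first, only, known or untested is meant among the compounds shown, and "the series" means these compounds.

Measured compounds:

- compound 1, `COc1cc(Cl)cc(-c2nn(-c3cccc(NC(=O)c4cccc(C(F)(F)F)c4)c3)cc2-c2ccncc2)c1`: in a functional assay on MDA-MB-231 cells (Homo sapiens) for inhibition, read by sulforhodamine B assay, with a stated time of 48 h, tested at 10 uM (on this read-out lower numbers stand for a stronger effect and higher numbers for a weaker effect at the one concentration tested), compound 1 gives 21.4%
- compound 2, `O=C(Nc1cccc(-n2cc(-c3ccncc3)c(-c3cc(O)cc(Cl)c3)n2)c1)c1cc(C(F)(F)F)cc(C(F)(F)F)c1`: in this assay compound 2 gives -34.6%

For the measured compounds named here, of the two numbers recorded in this assay, the one for compound 2 is the lowest, and its nearest neighbour is compound 1, which stands higher by an amount beyond the usual scatter. Compound 3, `COc1cc(Cl)cc(-c2nn(-c3cccc(NC(=O)c4cc(C(F)(F)F)cc(C(F)(F)F)c4)c3)cc2-c2ccncc2)c1`, has not yet been measured in this assay. It is built from compound 2 by a single change: methyl in place of hydrogen on an oxygen on an aromatic ring. Going by the values given here, compound 1 also carries a methoxy group, but it differs from compound 3 in its amide part as well, so no step between measured compounds isolates this change.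

Among the compounds with values here, with no measured step to lean on, the size and direction of the move in this assay from compound 2 to compound 3 are open. The expectation for compound 3 is a step of a number 29.6 percentage points higher from compound 2 to compound 3 (beyond the scatter), pointing toward weaker inhibition with a wide uncertainty. Compound 3 is therefore estimated at -5%, with a range from -45% to 35%.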

Compound 3, a percentage reported as activity, at one concentration (the size of the read-out at that concentration, not a potency): 56.7%
Estimate against measurement, compound 3: 61.7 percentage points below; the measured number lies above the stated range.
By their numbers in this assay, from the lowest: compound 2; then compound 1; then compound 3.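

Turning the hydroxy into methoxy on the 3-chloro-5-hydroxyphenyl ring gives a number 91.3 percentage points higher from compound 2 to compound 3 (beyond the scatter) in this assay, which shows that this one oxygen strongly affects the read-out: adding a single carbon atom there takes the number sharply upward, toward a weaker effect. The amide part matters as well, since with the methoxy group held in place, the swap of trifluoromethyl for hydrogen on an aromatic carbon, read in reverse from compound 3 back to compound 1, is the same change as the listed a number 35.3 percentage points higher from compound 1 to compound 3 (beyond the scatter), where the compound with the added trifluoromethyl has the higher number and so the weaker effect. No measurement at hand explains why either change moves the number as it does.

Going by these compounds, the two steps share only compound 3, so it remains open whether adding trifluoromethyl would have the same effect on a compound that keeps the hydroxy group. On these data alone, it is also open how this oxygen position would respond to other groups, such as an amine in place of the hydroxy or a longer chain such as ethoxy in place of the methoxy.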